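Swapping the Chain for a Pyridine Ring

The source may report more compounds than this note shows. Statements on the series, on what has been measured and on what is new or still open speak of the compounds shown alone.

Of the compounds shown here, three sharing one core have been measured in an ADME assay on the whole organism (plasma, strain Sprague-Dawley) for pharmacokinetics, with Rattus norvegicus as the target, at a dose of 10 mg/kg by the oral route; on this read-out higher numbers stand for higher exposure at the dose given and lower numbers for lower exposure. Compound 1, `Nc1cc(CN2CCC(C(=O)N3CCC(n4c(=O)n(C5CCCC5)c5cc(F)ccc54)CC3)CC2)ccn1`, gives 937 ng.h/mL. Compound 2, `Nc1cc(CN2CCC(C(=O)N3CCC(n4c(=O)n(-c5cc(F)cc(F)c5)c5cc(F)ccc54)CC3)CC2)ccn1`, gives 7280 ng.h/mL. Compound 3, `Nc1cc(CN2CCC(C(=O)N3CCC(n4c(=O)n(CCCC(F)(F)F)c5cc(F)ccc54)CC3)CC2)ccn1`, gives 2310 ng.h/mL, which places it second highest of the three, between the other two.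

Compound 4, `Nc1cc(CN2CCC(C(=O)N3CCC(n4c(=O)n(-c5ccccn5)c5cc(F)ccc54)CC3)CC2)ccn1`, has not yet been measured. It differs from compound 3 in one place: pyridin-2-yl in place of 4,4,4-trifluorobutyl on an aromatic nitrogen.

Two measured steps speak to this change. The most direct is a 3.2-fold lower number from compound 2 to compound 3 (0.50 log units; beyond the scatter), where a six-membered aromatic ring on that nitrogen gave way to the same chain; compound 4 reverses that kind of swap, putting an aromatic ring back in place of the chain. The step of a 7.8-fold higher number from compound 1 to compound 2 (0.89 log units; beyond the scatter) also shows that an aromatic ring on this nitrogen went with the highest number in the set. The step of a 2.5-fold higher number from compound 1 to compound 3 (0.39 log units; beyond the scatter) shows the chain itself stood modestly above cyclopentyl. Taken together, a modest increase in this assay is expected for compound 4, though pyridin-2-yl is not the same ring as in compound 2, so the size is uncertain.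

Compound 4 is therefore estimated at 4500 ng.h/mL, with a plausible range from 1500 ng.h/mL to 13000 ng.h/mL, which would mean an expected step of a 1.9-fold higher number from compound 3 to compound 4 (0.29 log units; within the scatter).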

Compound 4, area under the concentration-time curve: 5770 ng.h/mL
Compound 4: the middle estimate sits 1.3-fold (0.11 log units) below what was measured, and the stated range covers the measured number.
By their numbers in this assay, from the lowest: compound 1; then compound 3; then compounds 4 and 2 (each within the scatter of the next).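

In this assay, a 2.5-fold higher number from compound 3 to compound 4 (0.40 log units; beyond the scatter) shows directly that replacing 4,4,4-trifluorobutyl with an aromatic ring raises the number, and that this does not depend on the 3,5-difluorophenyl ring of compound 2: pyridin-2-yl, with a ring nitrogen and no fluorine, does the same. The two aromatic rings cannot be told apart here, since a 1.3-fold lower number from compound 2 to compound 4 (0.10 log units; within the scatter) is a difference no larger than repeated measurements would give, so the swap of 3,5-difluorophenyl for pyridin-2-yl leaves the read-out effectively unchanged. With a 6.2-fold higher number from compound 1 to compound 4 (0.79 log units; beyond the scatter) also on record, both aromatic groups now stand clearly above cyclopentyl and 4,4,4-trifluorobutyl on this nitrogen, and none of the four compounds goes against that split.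

Nothing measured here explains what lies behind these steps. Still open, as far as these compounds go, is whether the pattern extends to a pyridine attached through a different ring carbon, to a phenyl ring carrying an amine or a carboxylic acid, or to a five-membered aromatic ring such as thiazole on the same nitrogen.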